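Amide aryl swap on a piperazine-linked core

A few compounds are considered here, and "the series" means these few. Any claim that something is new, unique, unknown or untested is made for them only; others in the source may bear on it.

Measured compounds:
compound 1 `O=C(CN1CCN(c2nnc(Cc3ccncc3)c3ccccc23)CC1)Nc1cccc(F)c1`, 6130 nM
compound 2 `COc1ccc(NC(=O)CN2CCN(c3nnc(Cc4ccccc4)c4ccccc34)CC2)cc1OC`, 145000 nM
compound 3 `Cc1ccccc1NC(=O)CN1CCN(c2nnc(Cc3ccccc3)c3ccccc23)CC1`, 113000 nM

In a functional assay on HT-29 cells (Homo sapiens) for cytotoxicity, read by MTT assay, with a stated time of 72 h (on this read-out higher numbers stand for weaker inhibition and lower numbers for stronger inhibition), compound 1 gives the lowest of the three numbers, with compound 3 at 113000 nM and compound 2 at 145000 nM both well beyond the scatter above it. Compound 4 `Cc1ccc(NC(=O)CN2CCN(c3nnc(Cc4ccncc4)c4ccccc34)CC2)c(C)c1` is not yet measured. Its difference from compound 1 is 2,4-dimethylphenyl in place of 3-fluorophenyl on an amide-type nitrogen. Among the compounds with values here, no measured pair differs from each other in exactly this way: compound 2 and compound 3 differ from compound 1 both in the aryl on the amide nitrogen and elsewhere in the core, so their gap to compound 1 cannot be assigned to the aryl alone. Within the data shown here, the one step that touches this position is a 1.3-fold lower number from compound 2 to compound 3 (0.11 log units; within the scatter), which suggests that exchanging one aryl for another on the amide nitrogen moves the number little. For compound 4 a step of a 2.0-fold higher number from compound 1 to compound 4 (0.29 log units; within the scatter) is therefore expected, toward a somewhat weaker inhibition but with wide uncertainty. Compound 4 is estimated at 12000 nM, within 3000 nM to 50000 nM.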

Compound 4, half-maximal inhibitory concentration: 1930 nM
Beside the measured number, compound 4's estimate is 6.2-fold (0.79 log units) above it, and the stated range ends above it.
By their numbers in this assay, from the lowest: compound 4; then compound 1; then compounds 3 and 2 (each within the scatter of the next).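

In this assay the change from 3-fluorophenyl to 2,4-dimethylphenyl on the amide-type nitrogen gives a 3.2-fold lower number from compound 1 to compound 4 (0.50 log units; beyond the scatter) on the core of compound 1. This is a modest step, but it shows that the aryl at this position can move the number beyond the scatter. Within the data shown here, the only earlier step at this position was a 1.3-fold lower number from compound 2 to compound 3 (0.11 log units; within the scatter) on a different core, and it showed no such movement. No evidence is available that explains this step, and it cannot be divided between the added methyl groups and the lost fluorine.

As far as these compounds go, whether the step carries over to the core of compounds 2 and 3 stays open, since no aryl group appears on both cores. Also open, from the compounds shown here alone, is how an aryl group bearing an amine or a carboxylic acid would behave on this amide nitrogen.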